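The source may report more compounds than this note shows. Statements on the series, on what has been measured and on what is new or still open speak of the compounds shown alone.

Of the compounds shown here, three have been measured so far, all sharing one core and differing in the group that hangs from the carbonyl carbon. Compound 1 `O=C(Nc1cccc(-n2cc(-c3ccncc3)c(-c3ccc(Cl)c(O)c3)n2)c1)Nc1ccc(Cl)c(Cl)c1` gives 1160 nM in a functional assay on SK-MEL-5 cells (Homo sapiens) for inhibition, read by sulforhodamine B assay, with a stated time of 48 h (on this read-out lower numbers stand for stronger inhibition of growth and higher numbers for weaker inhibition of growth), and compound 3 `O=C(Nc1cccc(-n2cc(-c3ccncc3)c(-c3ccc(Cl)c(O)c3)n2)c1)Nc1cc(C(F)(F)F)cc(C(F)(F)F)c1` gives 1250 nM. Compound 2 `COc1cc(-c2nn(-c3cccc(NC(=O)c4ccc(Cl)c(C(F)(F)F)c4)c3)cc2-c2ccncc2)ccc1Cl` gives 6870 nM, the highest of the three numbers; its nearest neighbour is compound 3, whose number is lower by an amount beyond the scatter, and compound 1 lies further still in the same direction. On this read-out compound 2 is therefore the weakest inhibitor of growth among the measured set.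

Compound 4 `COc1cc(-c2nn(-c3cccc(NC(=O)Nc4cccc(C(F)(F)F)c4)c3)cc2-c2ccncc2)ccc1Cl` has not yet been measured. It differs from compound 2 in one place: (3-(trifluoromethyl)phenyl)amino in place of 4-chloro-3-(trifluoromethyl)phenyl on a carbonyl carbon. Within the data shown here, compound 1 and compound 3, whose carbonyl carbons likewise carry an amino group, both sit well below compound 2, though they also differ from compound 2 elsewhere, so no clean single step is available. The step from compound 2 to compound 4 is expected to go downward by about a 2.7-fold lower number from compound 2 to compound 4 (0.44 log units; beyond the scatter), beyond the scatter but not all the way to the level of compound 1. The value of compound 4 in this assay is estimated at 2500 nM, within a range from 800 nM to 8000 nM.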

Compound 4, concentration for total growth inhibition: 1390 nM
For compound 4 the middle estimate is 1.8-fold (0.25 log units) above the measured one, within the range that was stated.
By their numbers in this assay, from the lowest: compounds 1, 3 and 4 (each within the scatter of the next); then compound 2.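

Among these compounds, compounds 1 and 3 differ from compound 2 in more than one place, so this is the first clean reading of the group on the carbonyl carbon: in this assay the change gives a 4.9-fold lower number from compound 2 to compound 4 (0.69 log units; beyond the scatter) on otherwise identical structures, which means stronger inhibition of growth and shows that this position affects the read-out. The change is really two edits made together, since a nitrogen carrying a hydrogen-bond donor enters at the carbonyl carbon while the chlorine of the 4-chloro-3-(trifluoromethyl)phenyl group leaves, and the ring and the trifluoromethyl group stay. Nothing available explains why the number falls, and no measurement of any property of these compounds accompanies it.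

The pair cannot say whether the gain belongs to the added amino nitrogen or to the lost chlorine; 3-(trifluoromethyl)phenyl placed directly on the same carbonyl carbon would separate the two edits. It also leaves open whether the aromatic ring is needed at all at this position, a question that a saturated group such as cyclohexylamino on that carbonyl carbon would address.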